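The source may report more compounds than this note shows. Statements on the series, on what has been measured and on what is new or still open speak of the compounds shown alone.

Measured compounds:
- compound 1, `COc1ccc(N)c(C2=NN(C(C)=O)C(C)(C)S2)c1`: in an assay on isolated protein for inhibition of Nitric oxide synthase, inducible (Homo sapiens), read by scintillation counting, with a stated time of 30 min, tested at 50 uM (a higher number here means more inhibition at the concentration tested (going by the name of the read-out), a lower number less inhibition), compound 1 gives 77.1%
- compound 2, `CCCC(=O)N1N=C(c2cc(OC)ccc2N)SC1(C)C`: in this assay compound 2 gives 91.1%

Among the compounds with values here, compound 1 stands lowest of the two numbers measured so far; its nearest neighbour is compound 2, reached by a number 14 percentage points higher from compound 1 to compound 2 (beyond the scatter), a modest gain that lies beyond the scatter.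

The unmeasured compound 3, `COc1ccc(N)c(C2=NN(C(=O)c3ccccc3)C(C)(C)S2)c1`, differs from compound 1 in one place:

phenyl in place of methyl on a carbonyl carbon

Within the data shown here, the only measured step that bears on this change is the one from compound 1 to compound 2, where the acyl group on the ring nitrogen was enlarged by ethyl in place of hydrogen on a saturated chain carbon bound to a carbonyl carbon, and this assay rose by a number 14 percentage points higher from compound 1 to compound 2 (beyond the scatter). Among the measured compounds shown here, the change from acetyl to benzoyl also enlarges the same acyl group, though it brings a six-membered aromatic ring rather than a longer chain, so the direction of that one step is the only guide, and its size need not carry over.

For compound 3 the expected step is a number 7.9 percentage points higher from compound 1 to compound 3 (within the scatter), a modest rise with wide uncertainty. Compound 3 is therefore estimated at 85%, between 65% and 97%.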

Compound 3, a percentage reported as inhibition, at one concentration (the size of the read-out at that concentration, not a potency): 0%
Compound 3: the middle estimate sits 85 percentage points above what was measured, and the stated range ends above it.
By their numbers in this assay, from the lowest: compound 3; then compound 1; then compound 2.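

At the carbonyl carbon whose other neighbour is the amide-type nitrogen in a ring, adding carbon atoms does not move this assay in one direction. Acetyl to benzoyl gives a number 77.1 percentage points lower from compound 1 to compound 3 (beyond the scatter) and phenyl in place of propyl gives a number 91.1 percentage points lower from compound 2 to compound 3 (beyond the scatter) even though the chain extension from acetyl had raised the number. This position therefore distinguishes a saturated chain from a directly attached phenyl ring, and among the three compounds shown the change of this one group spans the whole range of the read-out. No measurement at hand accounts for the difference between the phenyl group and the saturated chains.

The compounds shown leave open whether the loss follows the aromatic ring itself or its direct attachment to the carbonyl carbon, a question that benzyl and cyclohexyl groups at the same place could separate. Also open, going by these compounds, is whether a chain longer than propyl keeps the higher number, and whether a phenyl ring carrying a methoxy group or an amine, or a pyridine ring in its place, recovers any inhibition.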